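A Ring Opened: Cyclopentyl Gives Way to Neopentyl

A few compounds are considered here, and "the series" means these few. Any claim that something is new, unique, unknown or untested is made for them only; others in the source may bear on it.

Of the compounds shown here, three on a shared core have been tested in a functional assay on the whole organism for inhibition, with Nicotiana tabacum as the target; on this read-out higher numbers stand for weaker inhibition and lower numbers for stronger inhibition. Compound 1 `Cc1nc(Nc2ccc(I)cc2)c2cc[nH]c2n1` gives 219000000 nM, compound 3 `COCCNc1[nH]c(C)nc2nccc1-2` gives 166000000 nM, and compound 2 `Cc1nc(NC2CCCC2)c2cc[nH]c2n1` gives 72400000 nM, the lowest of the three numbers and beyond the scatter from each of the others, so compound 2 stands as the strongest inhibitor of the set. Compound 4 `Cc1nc(NCC(C)(C)C)c2cc[nH]c2n1` remains unmeasured and differs from compound 2 in one place: neopentyl in place of cyclopentyl on a nitrogen on an aromatic ring. For the measured compounds named here, no step of this kind between measured compounds is available, so the expectation rests on the like size of the two groups alone. A step of a 1.4-fold higher number from compound 2 to compound 4 (0.14 log units; within the scatter) is expected, a small shift toward weaker inhibition that need not exceed the scatter. Compound 4 is therefore estimated at 100000000 nM, with a range from 40000000 nM to 250000000 nM.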

Compound 4, half-maximal inhibitory concentration: 200000000 nM
Estimate against measurement, compound 4: 2.0-fold (0.30 log units) below; low and high end bracket the measured number.
By their numbers in this assay, from the lowest: compound 2; then compounds 3, 4 and 1 (each within the scatter of the next).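

In this assay, replacing the cyclopentyl ring with neopentyl on a nitrogen on an aromatic ring gives a 2.8-fold higher number from compound 2 to compound 4 (0.44 log units; beyond the scatter). This shows that the position distinguishes between two groups of 5 carbon atoms, and the step lies beyond the usual scatter. The counts for the two groups differ only in the ring, since neither has hydrogen-bond donors, acceptors or a net charge, but no available evidence accounts for the step. The compounds shown leave open how cyclobutyl or cyclohexyl would compare with cyclopentyl. They also leave open whether an unbranched pentyl chain would match neopentyl.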